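Methoxy Added to the Core of Compound 3

The source may hold more compounds than are shown below. What is called first, only, known or untested is meant among the compounds shown, and "the series" means these compounds.

Measured so far:
compound 1, `C=C(Br)C(=O)Nc1ccc(/C=C/C(=O)c2ccccc2)cc1`: 3900 nM
compound 2, `C=C(Br)C(=O)Nc1ccc(/C=C/C(=O)c2cccc(OC)c2)cc1`: 2700 nM
compound 3, `COc1ccccc1/C=C/C(=O)c1ccc(N)cc1`: 25000 nM

In a functional assay on FM3A cells (Mus musculus) for antiproliferative activity, with a stated time of 48 h (on this read-out lower numbers stand for stronger inhibition and higher numbers for weaker inhibition), compound 1 gives 3900 nM and compound 2 gives 2700 nM. The two differ by methoxy in place of hydrogen on an aromatic carbon, and that step is a 1.4-fold lower number from compound 1 to compound 2 (0.16 log units; within the scatter). Compound 3 rests on a different core; the difference between the two cores is not broken down here, and in this assay compound 3 gives 25000 nM, the highest of the three numbers.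

Compound 4, `COc1ccc(/C=C/C(=O)c2ccc(N)cc2)c(OC)c1`, has not yet been measured. It differs from compound 3 by methoxy in place of hydrogen on an aromatic carbon. This is the same kind of change as that from compound 1 to compound 2, though not the same: there the place was meta to a large group, here it is meta to a methoxy group and para to a large group. Since the earlier step was a 1.4-fold lower number from compound 1 to compound 2 (0.16 log units; within the scatter), a step of similar size is expected, a 1.4-fold lower number from compound 3 to compound 4 (0.14 log units; within the scatter), giving an estimated 18000 nM for compound 4, with a range from 7000 nM to 45000 nM.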

Compound 4, half-maximal inhibitory concentration: 43000 nM
For compound 4 the middle estimate is 2.4-fold (0.38 log units) below the measured one, within the range that was stated.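

In this assay, methoxy in place of hydrogen on an aromatic carbon gives a 1.7-fold higher number from compound 3 to compound 4 (0.24 log units; within the scatter). Set beside the earlier step on the other core, this step shows no difference that exceeds the scatter: the same change on two cores in this assay, a 1.4-fold lower number (0.16 log units; within the scatter) from compound 1 to compound 2 and a 1.7-fold higher number (0.24 log units; within the scatter) from compound 3 to compound 4, 2.5-fold (0.40 log units) apart, within the scatter of two such steps. The change therefore carries across these two cores without a detectable difference, but neither step shows that methoxy has any effect on either core, and two pairs with the methoxy group in different surroundings cannot establish a rule for the series.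

The compounds shown leave open whether a hydroxy group, a fluorine atom or a longer alkoxy chain in the same place would give a step beyond the scatter. They also leave open whether such a step would carry from one core to the other.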